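One Ring Stereocentre Turned, Compound 2 to Compound 3

This account rests on a few compounds, and the source may have more. Where it says the series, first, only, none or still open, it means among the compounds named here.

Compound 1 `C=C1CCCC(C)(C)C1CC[C@]1(C)CC[C@@H]([C@@H](C)C(=O)O)OO1` reaches only a limit, not a number, in a functional assay on OVCAR-8 cells (Homo sapiens) for inhibition (on this read-out higher numbers stand for weaker inhibition of growth and lower numbers for stronger inhibition of growth), reported as > 10000 nM. Among the compounds with values here, compound 2 `C=C1CCC[C@H]2[C@](C)(CC[C@]3(C)CC[C@@H]([C@@H](C)C(=O)O)OO3)[C@@H](C)CC[C@]12C` is the only compound here with a number in this assay, where compound 2 gives 2530 nM. Compound 3 `C=C1CCC[C@H]2[C@](C)(CC[C@]3(C)CC[C@H]([C@@H](C)C(=O)O)OO3)[C@@H](C)CC[C@]12C` keeps every atom and bond of compound 2; (the two compounds have the same atoms and bonds and differ only in configuration as drawn: 1 of 7 stereo elements differ; a stereocentre at a saturated ring carbon is drawn S in compound 2 and R in compound 3). Within the data shown here, no measured pair isolates such a change, so the size of the step cannot be read from these two compounds. A modest weakening in this assay is expected, the step of a 1.8-fold higher number from compound 2 to compound 3 (0.25 log units; within the scatter) reaching a little beyond the scatter. For compound 3 the estimate in this assay is 4500 nM, within 1200 nM to 15000 nM.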

Compound 3, concentration for 50% growth inhibition: 1570 nM
The estimate for compound 3 lay 2.9-fold (0.46 log units) above the measured number; low and high end bracket the measured number.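

In this assay, turning this saturated ring carbon stereocentre from S to R gives a 1.6-fold lower number from compound 2 to compound 3 (0.21 log units; within the scatter), so on this read-out the two drawn configurations at this position cannot be told apart. This is the first pair shown that isolates a single stereocentre: the fact that compounds 2 and 3 differ only in the configuration as drawn. The compounds shown leave open whether this position stays as indifferent to configuration when a methyl ester or a primary amide stands in place of the carboxylic acid. They also leave open what turning any of the other stereocentres would do.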